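Amine nitrogen substituents: from compound 3 to compound 4

A few compounds are considered here, and "the series" means these few. Any claim that something is new, unique, unknown or untested is made for them only; others in the source may bear on it.

Values in an ADME assay on EA.hy 926 cells (Homo sapiens) for inhibition, read by sulforhodamine B assay, with a stated time of 72 h; a lower number here means a stronger inhibitor, a higher number a weaker inhibitor:
- Compound 1 `CCCNC(=C\C(=O)/C=C/c1ccc(O)c(OC)c1)/C=C/c1ccc(O)c(OC)c1`: > 25000 nM (a limit)
- Compound 2 `CC(C)CNC(=C\C(=O)/C=C/c1ccc(O)cc1)/C=C/c1ccc(O)cc1`: > 25000 nM (a limit)
- Compound 3 `CCC(C)NC(=C\C(=O)/C=C/c1ccc(O)cc1)/C=C/c1ccc(O)cc1`: > 25000 nM (a limit)

Compound 3 has only a limit, > 25000 nM, so its exact place in the series cannot be read. For the measured compounds named here, the whole series so far stands at the limit of > 25000 nM in this assay, at which 3 of the 3 values shown sit.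

Compound 4 `O=C(/C=C(/C=C/c1ccc(O)cc1)NC1CCCCC1)/C=C/c1ccc(O)cc1` carries cyclohexyl in place of sec-butyl on an amine nitrogen.

Going by the values given here, the only measured step that bears on this change is a step that the two limits leave unreadable from compound 2 to compound 3, which has sec-butyl in place of isobutyl on an amine nitrogen. Among the compounds with values here, it offers no size to carry over, and no measured compound has a numerical value. With so little to go on, no step beyond the scatter is expected in this assay, and no direction can be assigned. The expected step is a number no higher from compound 3 to compound 4 (the limit leaves the size open). A result reported only as a limit is the likeliest outcome. For compound 4 the estimated value is 25000 nM, with an expected range of 10000 nM to 60000 nM.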

Compound 4, half-maximal inhibitory concentration: 4200 nM
Beside the measured number, compound 4's estimate is 6.0-fold (0.77 log units) above it, outside the stated range (below it).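

In this assay, for the compounds shown here, the substituent on the amine nitrogen proves able to shift the read-out, which the earlier compounds could not show: cyclohexyl in place of sec-butyl gives an at least 5.9-fold lower number from compound 3 to compound 4 (0.77 log units; beyond the scatter), and cyclohexyl in place of isobutyl gives an at least 5.9-fold lower number from compound 2 to compound 4 (0.77 log units; beyond the scatter). Both sizes are only minimum figures, with the true gaps left open. Among the compounds shown, cyclohexyl on this nitrogen alone gives a number rather than a limit: the limit of > 25000 nM in this assay, at which 3 of the 4 values shown sit.

From the compounds shown here alone, whether the step depends on the ring itself or on the larger carbon count remains open, and a straight hexyl chain on the same nitrogen would separate the two. How much ring size matters also remains unsettled, a question that cyclopentyl or cycloheptyl at this nitrogen would address.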